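This account rests on a few compounds, and the source may have more. Where it says the series, first, only, none or still open, it means among the compounds named here.

Measured compounds:
compound 1 `CN1C(=O)C2(C(C#N)=C(N)Oc3cc4oc(-c5ccccc5)cc(=O)c4c(O)c32)c2cccc(Cl)c21` — > 50000 nM
compound 2 `COc1ccc2c(c1)C1(C(=O)N2Cc2ccccc2)C(C#N)=C(N)Oc2cc3oc(-c4ccccc4)cc(=O)c3c(O)c21` — > 50000 nM

In a functional assay on NCI-H1299 cells (Homo sapiens) for antiproliferative activity, read by MTT assay, with a stated time of 48 h (a higher number here means a weaker inhibitor, a lower number a stronger inhibitor), compound 1 gives only a limit, > 50000 nM. Compound 2 likewise gives only a limit in this assay, > 50000 nM. Among the measured compounds shown here, compound 2 therefore stands at no number at all; the two values shown both sit at the limit of > 50000 nM in this assay, at which 2 of the 2 values shown sit, so no step between measured compounds can be sized, and no direction of change is known within the pair. Compound 3 `N#CC1=C(N)Oc2cc3oc(-c4ccccc4)cc(=O)c3c(O)c2C12C(=O)N(Cc1ccccc1)c1ccc(Br)cc12` differs from compound 2 by bromo in place of methoxy on an aromatic carbon. The closest point of reference is compound 2, which gives only a limit in this assay, > 50000 nM. Nothing in the two measured values suggests a step beyond the scatter, in either direction, for a change of this kind. Compound 3 is accordingly expected to reach no measurable number in this assay, with an estimate of 60000 nM between 20000 nM and 200000 nM, and the expected step is a step that the limit leaves unreadable from compound 2 to compound 3.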

Compound 3, half-maximal inhibitory concentration: > 50000 nM
Compound 3 gave a limit, no number; the forecaster's own chance of this, stated with the estimate: 75%; the middle value lies beyond the limit too.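

In this assay compound 3 gives > 50000 nM, a limit and not a number. No step from compound 2 to compound 3 can therefore be read: the limit of > 50000 nM in this assay, at which 3 of the 3 values shown sit.

The compounds shown leave open how bromo and methoxy compare in this assay, and whether any of these compounds would reach a measurable value there.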